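The source may hold more compounds than are shown below. What is called first, only, known or untested is meant among the compounds shown, and "the series" means these compounds.

Compound 1, `COc1cc(OC)cc(C(=O)Nc2cccc(-c3oc4cc(-c5ccc(F)cc5)ccc4c(=O)c3O)c2)c1`: 23500 nM 
Compound 2, `O=C(Nc1cccc(-c2oc3cc(-c4ccc(F)cc4)ccc3c(=O)c2O)c1)c1cnc(Cl)nc1Cl`: > 100000 nM 

In a functional assay on HepG2 cells (Homo sapiens) for antiproliferative activity, read by CCK-8 assay, with a stated time of 72 h (a lower number here means a stronger inhibitor, a higher number a weaker inhibitor), compound 2 gives only a limit of the assay, > 100000 nM, not a measured number. Going by these compounds, compound 2 therefore sits at the limit of > 100000 nM in this assay, at which 1 of the 2 values shown sits, and its true value is unknown beyond that boundary. Compound 3, `CCCc1ccc(C(=O)Nc2cccc(-c3oc4cc(-c5ccc(F)cc5)ccc4c(=O)c3O)c2)cc1`, differs from compound 2 in one place: 4-propylphenyl in place of 2,4-dichloropyrimidin-5-yl on a carbonyl carbon. For the measured compounds named here, the single measured step that bears on this exchange is the earlier one, an at least 4.2-fold higher number from compound 1 to compound 2 (0.62 log units; beyond the scatter), which put a 2,4-dichloropyrimidin-5-yl ring where a carbon-only aromatic ring had been on the same carbonyl carbon. Compound 3 again carries a six-membered aromatic ring of carbon only at that carbonyl, so in this assay a lower number than the limit of compound 2 is expected, with the estimated step of an at least 5.0-fold lower number from compound 2 to compound 3 (0.69 log units; beyond the scatter). For compound 3 the expected value is 20000 nM, estimated to lie between 5000 nM and 100000 nM.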

Compound 3, half-maximal inhibitory concentration: 51500 nM
Estimate against measurement, compound 3: 2.6-fold (0.41 log units) below; the range from low to high includes it.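

In this assay, a six-membered ring of carbon only on this carbonyl carbon does not settle the number by itself: 4-propylphenyl in place of 3,5-dimethoxyphenyl gives a 2.2-fold higher number from compound 1 to compound 3 (0.34 log units; beyond the scatter). Replacing 2,4-dichloropyrimidin-5-yl with 4-propylphenyl gives an at least 1.9-fold lower number from compound 2 to compound 3 (0.28 log units; that floor lies within the scatter), so this exchange is not shown to be a real gain. Compound 2 has only a limit, not a measured number: the limit of > 100000 nM in this assay, at which 1 of the 3 values shown sits.

The compounds shown leave open whether a phenyl ring with a single methoxy group or a shorter chain such as ethyl would separate the effect of the chain from that of the methoxy groups. They also leave open how a phenyl ring carrying an amine or a carboxylic acid, or a saturated cyclohexyl ring, would behave on this carbonyl carbon.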